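The source may report more compounds than this note shows. Statements on the series, on what has been measured and on what is new or still open speak of the compounds shown alone.

Three compounds share one core and differ only in the group attached to a carbonyl carbon. In an ADME assay on Caco-2 cells (Homo sapiens) for permeability, in the apical to basolateral direction (on this read-out higher numbers stand for higher permeability and lower numbers for lower permeability), compound 1 `Cn1cncc1CN1CC(N(CC2CCN(C(=O)Nc3ccc(Br)cc3)CC2)S(=O)(=O)c2ccccn2)Cc2cc(C#N)ccc21` gives 0.6 10^-6 cm/s, compound 2 `CC(C)OC(=O)N1CCC(CN(C2Cc3cc(C#N)ccc3N(Cc3cncn3C)C2)S(=O)(=O)c2ccccn2)CC1` gives 1 10^-6 cm/s, and compound 3 `Cn1cncc1CN1CC(N(CC2CCN(C(=O)CC(C)(C)C)CC2)S(=O)(=O)c2ccccn2)Cc2cc(C#N)ccc21` gives 0.5 10^-6 cm/s. Compound 3 stands lowest on the numbers as written, yet the steps of a 1.2-fold lower number from compound 1 to compound 3 (0.08 log units; within the scatter) and a 2.0-fold lower number from compound 2 to compound 3 (0.30 log units; within the scatter), like a 1.7-fold higher number from compound 1 to compound 2 (0.22 log units; within the scatter), all fall within the scatter, so the three numbers cannot be told apart. Compound 4 `Cn1cncc1CN1CC(N(CC2CCN(C(=O)N3CCCC3)CC2)S(=O)(=O)c2ccccn2)Cc2cc(C#N)ccc21` differs from compound 3 by pyrrolidin-1-yl in place of neopentyl on a carbonyl carbon. Every measured step at this same carbonyl carbon stayed within the scatter, so no change beyond the scatter is expected here either: for compound 4 the expected step is a 1.2-fold higher number from compound 3 to compound 4 (0.08 log units; within the scatter). Compound 4 is therefore estimated at 0.6 10^-6 cm/s, with a range from 0.3 10^-6 cm/s to 1.2 10^-6 cm/s.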

Compound 4, apparent permeability: 0.6 10^-6 cm/s
The estimate for compound 4 equals the measured number at the digits printed; low and high end bracket the measured number.
By their numbers in this assay, from the lowest: compounds 3, 1, 4 and 2 (each within the scatter of the next).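

With pyrrolidin-1-yl, a ring joins the groups on this carbonyl carbon, and all three new steps stay within the scatter: a 1.2-fold higher number from compound 3 to compound 4 (0.08 log units; within the scatter), a 1.7-fold lower number from compound 2 to compound 4 (0.22 log units; within the scatter) and no change at the digits printed from compound 1 to compound 4 (within the scatter). Neopentyl and pyrrolidin-1-yl have the same count of heavy atoms, so exchanging an open carbon group for a nitrogen-linked ring of that size gives no readable difference here. No supporting evidence is available to explain these numbers. Still open, on these data alone, is whether piperazin-1-yl or a longer alkyl chain on this carbonyl carbon would move the number beyond the scatter.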